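Naphthalen-2-yl in place of tert-butylphenyl on the ester oxygen

A few compounds are considered here, and "the series" means these few. Any claim that something is new, unique, unknown or untested is made for them only; others in the source may bear on it.

Three compounds share one core and differ in the group carried on an oxygen next to a carbonyl group. Going by the values given here, in a functional assay on HeLa cells (Homo sapiens) for cytotoxicity, read by MTT assay, with a stated time of 48 h (on this read-out lower numbers stand for stronger inhibition and higher numbers for weaker inhibition), compound 3 `CC(C)(C)c1ccc(OC(=O)c2cn(-c3ccccc3)nc2-c2ccncc2)cc1` gives 35400 nM, the only outright number among the three values shown. Compound 2 `CCc1ccc(OC(=O)c2cn(-c3ccccc3)nc2-c2ccncc2)cc1` reaches only the limit of > 100000 nM in this assay. Compound 1 `O=C(Oc1ccc2ccccc2c1)c1cn(-c2ccccc2)nc1-c1cccnc1` likewise stops at the limit of > 100000 nM. Among the compounds with values here, the single measured step, an at least 2.8-fold lower number from compound 2 to compound 3 (0.45 log units; beyond the scatter), carries the reading off the limit of > 100000 nM in this assay, at which 2 of the 3 values shown sit, and into a measurable figure. Compound 4 `O=C(Oc1ccc2ccccc2c1)c1cn(-c2ccccc2)nc1-c1ccncc1` differs from compound 3 by naphthalen-2-yl in place of 4-(tert-butyl)phenyl on an oxygen next to a carbonyl group. Within the data shown here, no measured step covers this exchange; compound 1 carries the same naphthalen-2-yl group on an otherwise different core and sits at the limit. The expectation for compound 4 is therefore a weaker reading, a 2.0-fold higher number from compound 3 to compound 4 (0.30 log units; within the scatter), quite possibly back at the limit. Compound 4 is thus estimated at 70000 nM, with a range from 25000 nM to 200000 nM.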

Compound 4, half-maximal inhibitory concentration: > 100000 nM
Compound 4 gave a limit, no number (the forecaster's own chance of this, stated with the estimate: 60%); middle value at least 1.4-fold (0.15 log units) away from the limit.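

In this assay, putting naphthalen-2-yl in place of 4-(tert-butyl)phenyl on the oxygen next to a carbonyl group gives an at least 2.8-fold higher number from compound 3 to compound 4 (0.45 log units; beyond the scatter). The two groups have the same count of heavy atoms, all carbon, so that count alone does not keep the reading measurable, and the earlier step from ethyl to tert-butyl could not show this. The true size of the new step stays unknown because compound 4 gives only a limit, so the step is a minimum: the limit of > 100000 nM in this assay, at which 3 of the 4 values shown sit.

The steps to compound 4 from compound 2 and from compound 1 cannot be read, since both ends of each are limits, so the exchange of pyridin-3-yl for pyridin-4-yl has no size here. From the compounds shown here alone, whether an amine or a carboxylic acid in place of the tert-butyl group would lower the number further remains open.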